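Swapping the sulfonyl aryl group: from compound 1 to compound 4

The compounds below may be only part of what the source reports. "The series", "measured", "known", "first", "only" and "open" are said of these compounds alone.

Measured compounds in an ADME assay on microsomes from liver (Mus musculus) for metabolic stability, read by LC-MS, using NADPH, tested at 10 uM; on this read-out higher numbers stand for a longer-lived compound and lower numbers for a shorter-lived compound:
- compound 1, `Cc1cc(F)ccc1S(=O)(=O)N1CCN(c2ccc(C(=O)NCc3ccc(F)cc3)nn2)CC1`: 0.25 h
- compound 2, `Cc1ccccc1S(=O)(=O)N1CC=C(c2ccc(C(=O)NCc3ccc(F)cc3)nn2)CC1`: 0.0833 h
- compound 3, `Cc1ccccc1S(=O)(=O)N1CCN(c2cnc(C(=O)NCc3ccc(F)cc3)cn2)CC1`: 0.05 h

Among these three, compound 1 gives the highest number in this assay, so it is the longest-lived of the set. Its nearest neighbour is compound 2, whose number is lower by a margin beyond the usual scatter; compound 3 lies further away still, also beyond the scatter. Compound 1 is therefore the reference from which the next step is taken.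

Compound 4, `Nc1ncccc1S(=O)(=O)N1CCN(c2ccc(C(=O)NCc3ccc(F)cc3)nn2)CC1`, has not yet been measured. It differs from compound 1 in one place: 2-aminopyridin-3-yl in place of 4-fluoro-2-methylphenyl on a sulfonyl sulfur. The rest of the molecule, including the shared core and the amide portion, stays the same.

Going by the values given here, no measured pair shows exactly this change, so its effect can only be guessed. The expectation is a modest step, most likely within the scatter, in either direction. On that basis compound 4 is estimated at 0.3 h in this assay, with a likely range from 0.1 h to 0.9 h, which is expected to be a step of a 1.2-fold higher number from compound 1 to compound 4 (0.08 log units; within the scatter).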

Compound 4, half-life: 0.317 h
The estimate for compound 4 lay 1.1-fold (0.02 log units) below the measured number; the range from low to high includes it.
By their numbers in this assay, from the lowest: compounds 3 and 2 (each within the scatter of the next); then compounds 1 and 4 (each within the scatter of the next).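

In this assay, putting 2-aminopyridin-3-yl in place of 4-fluoro-2-methylphenyl on a sulfonyl sulfur gives a 1.3-fold higher number from compound 1 to compound 4 (0.10 log units; within the scatter), so this read-out does not separate the two compounds. Going by these compounds alone, this is the first look at this position, and for this one pair, an aromatic ring of carbon only and a ring with a hetero atom and a hydrogen-bond donor give half-lives that match within the scatter. Nothing measured here gives a reason for this outcome.

Going by these compounds, the swap alters the ring and its groups all at once, so the separate roles of the ring nitrogen and the amine remain open, and a simple pyridin-3-yl or a 2-methoxypyridin-3-yl could help to divide them. On these data alone, whether the same swap behaves alike on the cores of compound 2 and compound 3 is also open.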